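Trihydrazone Analogues of a Trimethoxybenzoyl Hydrazide Series

The source may hold more compounds than are shown below. What is called first, only, known or untested is meant among the compounds shown, and "the series" means these compounds.

The study examines a trimethoxybenzoyl hydrazide core in a functional assay on PC-3 cells (Homo sapiens) for antiproliferative activity, read by MTT assay, tested at 1 uM; on this read-out higher numbers stand for a stronger effect at the one concentration tested and lower numbers for a weaker effect. Compound 1, `COc1cc(C(=O)N/N=C/c2ccccc2C(F)(F)F)cc(OC)c1OC`, gives 45% in this assay. Compound 2, `COc1cc(C2=NN(C(C)=O)C(c3cccc(OC)c3OC)O2)cc(OC)c1OC`, gives 35% in this assay. Compound 1 and compound 2 lie within the usual scatter of each other, so the two numbers cannot be told apart on this read-out.

Compound 3, `COc1cc(C(=O)N/N=C/c2ccccc2F)cc(OC)c1OC`, has not yet been measured in this assay. It differs from compound 1 by a single change: fluoro in place of trifluoromethyl on an aromatic carbon. Among the compounds with values here, no measured pair within the set shows what such a change does, so the direction of the step cannot be read from the data at hand.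

Compound 3 is therefore expected to behave much like compound 1, with a step of a number 7 percentage points lower from compound 1 to compound 3 (within the scatter) in this assay that stays within the usual scatter. The estimated inhibition for compound 3 is 38%, with a range from 15% to 60%.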

Compound 3, a percentage reported as inhibition, at one concentration (the size of the read-out at that concentration, not a potency): 70.6%
Estimate against measurement, compound 3: 32.6 percentage points below; the whole stated range lies below it.
By their numbers in this assay, from the lowest: compounds 2 and 1 (each within the scatter of the next); then compound 3.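

Replacing trifluoromethyl with fluoro on an aromatic carbon ortho to a large group gives, in this assay, a number 25.6 percentage points higher from compound 1 to compound 3 (beyond the scatter). Within the data shown here, this is the first measured single change in the set, and it shows that the read-out responds to the group at this place: the fluoro compound stands clear of the trifluoromethyl compound, rather than within the scatter. Nothing at hand bears on what lies behind this difference.

The compounds shown leave open how a chlorine atom, an amine or a nitrile on this same carbon would read, so one pair cannot say whether the number follows the size of the group or something else about it. They also leave open whether the same exchange on another carbon of this ring would give a comparable step.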